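The source may report more compounds than this note shows. Statements on the series, on what has been measured and on what is new or still open speak of the compounds shown alone.

Compound 1 `N#Cc1c(N2CCC(c3ccccc3)CC2)ccn(CC2CC2)c1=O` stands at the top of the three measured compounds in a functional assay on CHO cells for positive allosteric modulation of metabotropic glutamate receptor 2 (Homo sapiens), with a stated time of 30 min (on this read-out lower numbers stand for smaller maximal responses and higher numbers for larger maximal responses), where compound 1 reaches 309%. Compound 2 `N#Cc1c(N2CCC(c3ccccc3Cl)CC2)ccn(CC2CC2)c1=O` gives 259% and compound 3 `N#Cc1c(N2CCC(c3cc(F)cc(F)c3)CC2)ccn(CC2CC2)c1=O` gives 234%, so both sit below compound 1: a number 50 percentage points lower from compound 1 to compound 2 (beyond the scatter), a number 75 percentage points lower from compound 1 to compound 3 (beyond the scatter), and further a number 25 percentage points lower from compound 2 to compound 3 (beyond the scatter).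

Compound 4 `O=c1c(C(F)(F)F)c(N2CCC(c3ccccc3)CC2)ccn1CC1CC1` differs from compound 1 in a single respect: trifluoromethyl in place of cyano on an aromatic carbon. The group that is exchanged sits on the shared core, two atoms from the ring nitrogen, whereas every measured step altered the phenyl ring or its substituents on the saturated ring carbon. Within the data shown here, none of the measured steps therefore bears directly on this change; they show only that one substituent exchange can move the maximal response by a large margin, and that compound 1, as the highest value, has the most room to fall. Among the measured compounds shown here, with no direct precedent, the expectation for compound 4 is a modest decrease, a number 59 percentage points lower from compound 1 to compound 4 (beyond the scatter), with wide uncertainty in both directions. Compound 4 is thus estimated at 250% in this assay, within a range from 150% to 330%.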

Compound 4, largest response reached (Emax), in percent of the reference or control that the assay uses: 239%
For compound 4 the middle estimate is 11 percentage points above the measured one; the range from low to high includes it.
By their numbers in this assay, from the lowest: compounds 3 and 4 (each within the scatter of the next); then compound 2; then compound 1.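

Moving the change from the phenyl ring to the shared core still has a clear effect: exchanging cyano for trifluoromethyl, on the aromatic carbon two atoms from the ring nitrogen, gives a number 70 percentage points lower from compound 1 to compound 4 (beyond the scatter) in this assay. This shows that the maximal response depends on this core position as well as on the phenyl substituents, and that compound 4 keeps a substantial response at 239% without the cyano group, its triple bond or its hydrogen-bond acceptor, since trifluoromethyl brings neither of these and has more heavy atoms. Nothing available shows which of these differences matters, so the reason for the lower number remains unexplained.

The compounds shown leave open how other groups on this same carbon, such as a methyl group, a chlorine atom, a carboxylic acid or an amine, would compare with cyano and trifluoromethyl. They also leave open whether trifluoromethyl would have a similar effect on a compound carrying a 2-chlorophenyl or 3,5-difluorophenyl group, or whether changes at the two sites would simply add together.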